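Swapping an ethoxy for a chloro: expected microsomal clearance

This account rests on a few compounds, and the source may have more. Where it says the series, first, only, none or still open, it means among the compounds named here.

Measured compounds:
compound 1, `CCOC(=O)c1c(-c2cccc(-c3ccccc3)c2)[nH]c2cc(OC)ccc2c1=O`: 5.7 mL.min-1.g-1
compound 2, `CCOC(=O)c1c(-c2cccc(OC)c2)[nH]c2cc(OC)ccc2c1=O`: 7.9 mL.min-1.g-1
compound 3, `CCOC(=O)c1c(-c2cccc(OCC)c2)[nH]c2cc(OC)ccc2c1=O`: 12 mL.min-1.g-1

All three numbers come from an in vitro ADME assay on microsomes from liver (Mus musculus, strain CD1) for metabolic stability, read by HPLC, with a stated time of 4 h; a lower number here means slower removal, a higher number faster removal of the compound. Compound 3 has the highest of the three numbers, although its gap to compound 2 is within the scatter; only its gap to compound 1 is beyond it.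

Compound 4, `CCOC(=O)c1c(-c2cccc(Cl)c2)[nH]c2cc(OC)ccc2c1=O`, is not yet measured. chloro in place of ethoxy on an aromatic carbon The three measured compounds differ from one another at this same aromatic carbon, so all three steps bear on the change: a 1.4-fold higher number from compound 1 to compound 2 (0.14 log units; within the scatter), a 2.1-fold higher number from compound 1 to compound 3 (0.32 log units; beyond the scatter) and a 1.5-fold higher number from compound 2 to compound 3 (0.18 log units; within the scatter). The two groups without oxygen (phenyl in compound 1) or with the smaller alkoxy (compound 2) sit at lower numbers than the ethoxy of compound 3, and the largest step seen, from compound 1 to compound 3, is still only modest. A step of similar size, downward, is therefore expected, with compound 4 landing near compounds 1 and 2; the expected step is a 2.0-fold lower number from compound 3 to compound 4 (0.30 log units; within the scatter). Compound 4 is expected to give 6 mL.min-1.g-1 in this assay, with a range from 3 mL.min-1.g-1 to 12 mL.min-1.g-1.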

Compound 4, intrinsic clearance in microsomes: 16 mL.min-1.g-1
Compound 4: the middle estimate sits 2.7-fold (0.43 log units) below what was measured, outside the stated range (above it).
By their numbers in this assay, from the lowest: compounds 1, 2, 3 and 4 (each within the scatter of the next, the first and the last beyond it).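

Putting chloro in place of ethoxy on this aromatic carbon gives no clear shift in this assay, with a 1.3-fold higher number from compound 3 to compound 4 (0.12 log units; within the scatter), so a group with no oxygen can stand level with ethoxy here. Chloro does stand apart from the other two groups, with a 2.0-fold higher number from compound 2 to compound 4 (0.31 log units; beyond the scatter) and a 2.8-fold higher number from compound 1 to compound 4 (0.45 log units; beyond the scatter), though both steps are modest. Nothing measured here bears on the cause of this result.

Going by these compounds, it remains open whether an amine, a carboxylic acid or a longer chain such as propoxy on this carbon would stand with compound 4 or nearer compound 1. Also open, on these data alone, is whether swapping ethoxy for chloro would read the same on another carbon of this ring.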